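The source may hold more compounds than are shown below. What is called first, only, known or untested is meant among the compounds shown, and "the series" means these compounds.

Compound 1 `CC1CCN(C2CCN(S(=O)(=O)c3cnc(Cl)s3)CC2)CC1`: 1800 nM
Compound 2 `Cc1nc(Cl)sc1S(=O)(=O)N1CCC(N2CCC(C)CC2)CC1`: 1.6 nM

Among the measured compounds shown here, in a functional assay on DLD-1 cells (Homo sapiens) for antiproliferative activity, read by CellTiter-Glo, with a stated time of 72 h (on this read-out lower numbers stand for stronger inhibition and higher numbers for weaker inhibition), compound 2 stands at the lowest of the two numbers measured so far. Its nearest neighbour is compound 1, and the step of a 1100-fold lower number from compound 1 to compound 2 (3.05 log units; beyond the scatter) shows how far apart the two lie. Compound 3 `CC1CCN(C2CCN(S(=O)(=O)c3sc(Cl)nc3C3CC3)CC2)CC1` has not yet been measured in this assay. It differs from compound 2 in one place: cyclopropyl in place of methyl on an aromatic carbon. For the measured compounds named here, the only measured step, a 1100-fold lower number from compound 1 to compound 2 (3.05 log units; beyond the scatter), concerns a different change at the same aromatic carbon, the arrival of the methyl, and it was large. Going by the values given here, whether enlarging that methyl to a cyclopropyl keeps, improves or partly undoes that gain cannot be read from compound 1 and compound 2 alone; the single measured step shows only that this position matters a great deal to the number. The expectation for compound 3 is therefore a step of about a 1.9-fold higher number from compound 2 to compound 3 (0.27 log units; within the scatter), that is a modest drift toward a higher number or none beyond the scatter. Compound 3 is expected to give about 3 nM, with a likely range from 0.8 nM to 15 nM.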

Compound 3, half-maximal inhibitory concentration: > 5000 nM
Compound 3: a limit, no number; the forecaster's own chance of this, stated with the estimate: 2%; middle value at least 1600-fold (3.22 log units) from the limit.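

Compound 3 gives no number in this assay, only a limit of the assay: the limit of > 5000 nM in this assay, at which 1 of the 3 values shown sits.

Even so, the change of methyl to cyclopropyl on this aromatic carbon gives an at least 3100-fold higher number from compound 2 to compound 3 (3.49 log units; beyond the scatter), so the large gain that came with the methyl does not carry over to this other carbon group. Set against the hydrogen, cyclopropyl gives an at least 2.7-fold higher number from compound 1 to compound 3 (0.44 log units; beyond the scatter), which places compound 3 behind compound 1 as well, so among these three compounds the read-out depends on which group sits here and not merely on whether the hydrogen has been replaced.

From the compounds shown here alone, how far beyond the limit compound 3 truly lies remains unknown, and so does the exact size of the loss. Going by these compounds, it is also open whether the sharp drop comes only with the ring or already with a simple ethyl group, and whether an amine or a methoxy group on this same carbon would keep any of the strength seen with the methyl.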